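This account rests on a few compounds, and the source may have more. Where it says the series, first, only, none or still open, it means among the compounds named here.

Measured so far:
Compound 1 `CC1=CC[C@H]2[C@H](CC[C@]2(C)O)C(C)(C)[C@@H]1CC[C@H]1[C@]2(C)CC[C@H](OC(=O)NCc3ccccc3)C(C)(C)O[C@H]2CC[C@@]1(C)O`: 40300 nM
Compound 2 `CC1=CC[C@H]2[C@H](CC[C@]2(C)O)C(C)(C)[C@@H]1CC[C@H]1[C@]2(C)CC[C@H](OC(=O)c3ccc(Cl)c(Cl)c3)C(C)(C)O[C@H]2CC[C@@]1(C)O`: 8100 nM

Within the data shown here, in a functional assay on MDA-MB-231 cells (Homo sapiens) for antiproliferative activity, read by MTT assay, with a stated time of 72 h (on this read-out lower numbers stand for stronger inhibition and higher numbers for weaker inhibition), compound 2 gives 8100 nM, the lowest of the two numbers; its only neighbour is compound 1, and the single measured step is a 5.0-fold lower number from compound 1 to compound 2 (0.70 log units; beyond the scatter). Compound 3 `CC1=CC[C@H]2[C@H](CC[C@]2(C)O)C(C)(C)[C@@H]1CC[C@H]1[C@]2(C)CC[C@H](OC(=O)c3ccc([N+](=O)[O-])o3)C(C)(C)O[C@H]2CC[C@@]1(C)O` differs from compound 2 by 5-nitrofuran-2-yl in place of 3,4-dichlorophenyl on a carbonyl carbon. That measured step also changed the group on the carbonyl carbon, yet its entering group was different, so it bears only loosely here, and no step beyond the scatter is expected. Compound 3 is therefore estimated at 10000 nM (range 3000 nM to 40000 nM), an expected step of a 1.2-fold higher number from compound 2 to compound 3 (0.09 log units; within the scatter).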

Compound 3, half-maximal inhibitory concentration: 11100 nM
Beside the measured number, compound 3's estimate is 1.1-fold (0.05 log units) below it, and the stated range covers the measured number.
By their numbers in this assay, from the lowest: compounds 2 and 3 (each within the scatter of the next); then compound 1.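

In this assay, 5-nitrofuran-2-yl in place of 3,4-dichlorophenyl gives a 1.4-fold higher number from compound 2 to compound 3 (0.14 log units; within the scatter) and so two very different rings on this carbonyl carbon read alike. Set against benzylamino, the same ring gives a 3.6-fold lower number from compound 1 to compound 3 (0.56 log units; beyond the scatter) and so the lower number seen with compound 2 is not tied to the dichlorophenyl ring alone. Nothing shown here explains why these groups read as they do.

Still open, from the compounds shown here alone, is how a saturated ring such as cyclohexyl, a longer alkyl chain or a carboxylic acid at this place would read. Also open, going by these compounds, is whether any group here can reach far lower numbers.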